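The source may hold more compounds than are shown below. What is called first, only, known or untested is meant among the compounds shown, and "the series" means these compounds.

Measured so far:
- Compound 1, `CCC1=C(O)c2c(oc(-c3ccc(F)cc3)cc2=O)C(CC)(CC)C1=O`: 1.85 uM
- Compound 2, `CCC1=C(O)c2c(oc(-c3ccccc3C(F)(F)F)cc2=O)C(CC)(CC)C1=O`: 43.1 uM
- Compound 3, `CCC1=C(O)c2c(oc(-c3cc(Cl)c(OC)c(OC)c3)cc2=O)C(CC)(CC)C1=O`: 8.4 uM

Three compounds share one core and differ only in the aromatic group attached to it. In a functional assay on KBVIN cells (Homo sapiens) for antiproliferative activity, read by sulforhodamine B assay, with a stated time of 3 days (on this read-out lower numbers stand for an effect already at smaller amounts and higher numbers for an effect only at larger amounts of compound), compound 1 gives 1.85 uM, the lowest number of the three. Compound 3 gives 8.4 uM, a gap that lies beyond the scatter, and compound 2 gives 43.1 uM, the largest number and the furthest from compound 1.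

Compound 4, `CCC1=C(O)c2c(oc(-c3cc(C)c(O)c(C)c3)cc2=O)C(CC)(CC)C1=O`, has not yet been measured. It differs from compound 1 in one place: 4-hydroxy-3,5-dimethylphenyl in place of 4-fluorophenyl on an aromatic carbon. The entering group brings one hydrogen-bond donor and one hydrogen-bond acceptor, where the leaving 4-fluorophenyl had none, and it is larger by two heavy atoms.

For the measured compounds named here, no measured pair shows this exact change, so the expectation rests on the spread seen across the three aromatic groups. Both changes away from the 4-fluorophenyl of compound 1 raised the number, and a change of similar weight is expected here. Compound 4 is estimated at 6 uM, with a likely range from 1.5 uM to 25 uM, meaning an expected step of a 3.2-fold higher number from compound 1 to compound 4 (0.51 log units; beyond the scatter).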

Compound 4, concentration for half-maximal effect: 8.9 uM
For compound 4 the middle estimate is 1.5-fold (0.17 log units) below the measured one; measured number inside the range.
By their numbers in this assay, from the lowest: compound 1; then compounds 3 and 4 (each within the scatter of the next); then compound 2.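

Replacing the 4-fluorophenyl of compound 1 with 4-hydroxy-3,5-dimethylphenyl gives, in this assay, a 4.8-fold higher number from compound 1 to compound 4 (0.68 log units; beyond the scatter), so this position does not accept a group bearing a hydrogen-bond donor and acceptor without a loss compared with 4-fluorophenyl. Compound 4 also falls within the scatter of compound 3, and 4-fluorophenyl in compound 1 still gives the lowest number of the four compounds. No outside evidence is available to explain this step.

The change swaps the fluorine for a hydroxy group and adds methyl groups at once, so the compounds shown cannot say which part accounts for the step. A plain 4-hydroxyphenyl or 3,5-dimethylphenyl group would separate the two parts, and an amine on the ring remains an open case as well.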